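Removing a Second Hydroxy from a Trimethoxy-Derived Hydrazone Carbamate

This account rests on a few compounds, and the source may have more. Where it says the series, first, only, none or still open, it means among the compounds named here.

Compound 1 `COc1cc(/C=N/NC(=O)OCc2ccccc2)cc(OC)c1O` and compound 2 `COc1cc(/C=N/NC(=O)OCc2ccccc2)cc(O)c1O` share one core and were both tested in a functional assay on cells (Mus musculus) for cytotoxicity, read by MTT assay, with a stated time of 24 h, tested at 1 uM; on this read-out higher numbers stand for a stronger effect at the one concentration tested and lower numbers for a weaker effect. In this assay compound 1 gives 45%, while compound 2 gives 34%. Among the measured compounds shown here, the single change between them, hydrogen in place of methyl on an oxygen on an aromatic ring, produced a number 11 percentage points lower from compound 1 to compound 2 (beyond the scatter). On the two numbers available compound 2 therefore stands lowest, with compound 1 the nearest and higher value.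

Compound 3 `COc1cc(/C=N/NC(=O)OCc2ccccc2)ccc1O` is the next step from compound 2, with hydrogen in place of hydroxy on an aromatic carbon. For the measured compounds named here, no measured step removes a hydroxy outright; the only step seen, from compound 1 to compound 2, swapped methyl for hydrogen on oxygen and lowered the read-out modestly. That step does not bear directly on the present change, so the expectation rests on weak ground. A small further decrease, or no change beyond the scatter, is expected, as a number 4 percentage points lower from compound 2 to compound 3 (within the scatter). For compound 3 in this assay the estimated value is 30%, within a range from 15% to 45%.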

Compound 3, a percentage reported as activity, at one concentration (the size of the read-out at that concentration, not a potency): 73%
Estimate against measurement, compound 3: 43 percentage points below, and the stated range ends below it.
By their numbers in this assay, from the lowest: compound 2; then compound 1; then compound 3.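

In this assay, the aromatic carbon ortho to a hydroxy group proves far more sensitive than the earlier pair suggested: hydrogen in place of hydroxy there gives a number 39 percentage points higher from compound 2 to compound 3 (beyond the scatter), a large step and in the opposite direction to the one seen before. Hydrogen in place of methoxy at the same carbon points the same way, with a number 28 percentage points higher from compound 1 to compound 3 (beyond the scatter), so among these three compounds the one with no oxygen group at this carbon gives the strongest effect at the single concentration tested, whereas hydroxy and methoxy both go with lower numbers. Nothing measured here accounts for this rise.

The compounds shown leave open whether the gain belongs to hydrogen itself or would also appear with another small group at this carbon, such as fluorine, methyl or an amine, and whether a longer chain on the oxygen, such as ethoxy, would lower the number as methoxy does. As far as these compounds go, since each compound has a read-out at only one concentration, whether the same order of stronger and weaker effects would hold at other concentrations also remains open.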